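The compounds below may be only part of what the source reports. "The series", "measured", "known", "first", "only" and "open" are said of these compounds alone.

compound 1 `CC(C)(C)c1ccc(-c2oc3cc(O)cc(O)c3c(=O)c2O)cc1` gives 709000 nM
compound 2 `O=C(/C=C/c1ccco1)c1ccccc1O` gives 4270000 nM
compound 3 `O=C(/C=C/C=C/c1ccccc1)c1ccccc1` gives 113000000 nM

In a physicochemical assay, read by spectrophotometry, with a stated time of 20 min (on this read-out higher numbers stand for weaker inhibition and lower numbers for stronger inhibition), compound 1 has the lowest number of the three, and its gaps to compound 2 and to compound 3 both lie beyond the scatter. Compound 4 `O=c1c(O)c(-c2ccc(Cl)cc2)oc2cc(O)cc(O)c12` keeps the core of compound 1 but has chloro in place of tert-butyl on an aromatic carbon and no other change. Within the data shown here, no measured pair here shows this exchange, and compound 2 and compound 3 do not share that core. The expectation therefore rests on compound 1 alone, with its 709000 nM as the anchor. The step of a 1.1-fold higher number from compound 1 to compound 4 (0.02 log units; within the scatter) is expected to stay within the scatter, with neither direction favoured. Compound 4 is estimated at 750000 nM with an expected range from 250000 nM to 2300000 nM in this assay once measured.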

Compound 4, half-maximal inhibitory concentration: 27900000 nM
The estimate for compound 4 lay 37-fold (1.57 log units) below the measured number, outside the stated range (above it).
By their numbers in this assay, from the lowest: compound 1; then compound 2; then compound 4; then compound 3.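

In this assay, chloro in place of tert-butyl on an aromatic carbon gives a 39-fold higher number from compound 1 to compound 4 (1.59 log units; beyond the scatter), so inhibition is weaker with chloro at this position. Among these compounds, this is the first sign that a single exchange at this position, with the rest of the core of compound 1 unchanged, can move the read-out well beyond the scatter. No measurement at hand gives a reason for this step. As far as these compounds go, whether a methoxy group or an amine at this carbon would lie nearer compound 1 or compound 4 remains open. Also open, from the compounds shown here alone, is whether the same exchange would give a step of this size on another core.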